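A few compounds are considered here, and "the series" means these few. Any claim that something is new, unique, unknown or untested is made for them only; others in the source may bear on it.

Compound 1 `Fc1cccc(Nc2nc3nonc3nc2Nc2ccccc2F)c1` is the starting point. Among the measured compounds shown here, in an assay on mitochondria from L6 cells (Rattus norvegicus) for activation, with a stated time of 90 min (on this read-out lower numbers stand for an effect already at smaller amounts and higher numbers for an effect only at larger amounts of compound), compound 1 gives 190 nM, the lowest of the three numbers measured so far. Compound 2 `Fc1ccc(Nc2nc3nonc3nc2Nc2ccccc2F)c(F)c1` gives 300 nM in this assay; the step of a 1.6-fold higher number from compound 1 to compound 2 (0.20 log units; within the scatter) lies within the scatter, so these two cannot be told apart. Compound 3 `Cc1ccccc1Nc1nc2nonc2nc1Nc1ccccc1F` gives 1100 nM, and the step of a 5.8-fold higher number from compound 1 to compound 3 (0.76 log units; beyond the scatter) is beyond the scatter, as is a 3.7-fold higher number from compound 2 to compound 3 (0.56 log units; beyond the scatter).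

Compound 4 `Fc1ccccc1Nc1nc2nonc2nc1Nc1cccc(C(F)(F)F)c1` has not been measured. It differs from compound 1 in this way: trifluoromethyl in place of fluoro on an aromatic carbon. The measured steps all swap one whole aryl group for another on the same nitrogen, whereas this change keeps the ring of compound 1 and alters only the group on one aromatic carbon, so none of them bears on it directly. The two fluorinated rings of compounds 1 and 2 sit close together, while the 2-methylphenyl of compound 3 costs a modest amount; a small fluorinated substituent swapped for a larger one may therefore move the number a little in either direction, most likely not beyond the scatter. Compound 4 is expected to give 250 nM, between 90 nM and 700 nM, which means an expected step of a 1.3-fold higher number from compound 1 to compound 4 (0.12 log units; within the scatter).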

Compound 4, half-maximal effective concentration: < 1000 nM
Compound 4: a limit, no number; the forecaster's own chance of this, stated with the estimate: 5%; the middle value lies beyond the limit too.
By their numbers in this assay, from the lowest: compounds 1 and 2 (each within the scatter of the next); then compound 3.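

In this assay compound 4 gives < 1000 nM, which is a limit and not a number. The step from compound 1 to compound 4 therefore cannot be read. The compounds shown leave open whether trifluoromethyl in place of fluoro on this ring changes the number at all and, if so, in which direction.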